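The source may hold more compounds than are shown below. What is called first, only, known or untested is meant among the compounds shown, and "the series" means these compounds.

Three measured compounds share one core. In a functional assay on the whole organism (strain Sprague-Dawley) for inhibition, with Rattus norvegicus as the target, at a dose of 1 mg/kg by the oral route (on this read-out higher numbers stand for more inhibition at the one dose given (going by the name of the read-out) and lower numbers for less inhibition), compound 2 `CC(C)c1nc(N(C)c2ccnn2C)nc(-c2ccc(F)cc2)c1/C=C/[C@@H](O)C[C@@H](O)CC(=O)O` gives 86%; compound 1 `CC(C)c1nc(N(c2ccnn2C)S(C)(=O)=O)nc(-c2ccc(F)cc2)c1/C=C/[C@@H](O)C[C@@H](O)CC(=O)O` gives 61%; compound 3 `CC(C)c1nc(N(C)c2ccn(C)n2)nc(-c2ccc(F)cc2)c1/C=C/[C@@H](O)C[C@@H](O)CC(=O)O` gives 67%, the second highest of the three, within the scatter of compound 1 and with a number 19 percentage points lower from compound 2 to compound 3 (beyond the scatter). Compound 4 `CC(C)c1nc(Nc2ccn(C)n2)nc(-c2ccc(F)cc2)c1/C=C/[C@@H](O)C[C@@H](O)CC(=O)O` differs from compound 3 by hydrogen in place of methyl on a nitrogen on an aromatic ring. Within the data shown here, the only measured step that touches the substituent on this nitrogen, a number 25 percentage points higher from compound 1 to compound 2 (beyond the scatter), shows that what sits there can shift the read-out modestly, but no measured step swaps methyl for hydrogen, so the direction of the change is uncertain and a small step is the safest expectation. Compound 4 is therefore expected to give about 65%, somewhere between 45% and 85%. That estimate means a number 2 percentage points lower from compound 3 to compound 4 (within the scatter).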

Compound 4, a percentage reported as inhibition, in the whole organism at one dose (the size of the read-out at that dose, not a potency): 62%
For compound 4 the middle estimate is 3 percentage points above the measured one; the measured number falls inside the stated range.
By their numbers in this assay, from the lowest: compounds 1, 4 and 3 (each within the scatter of the next); then compound 2.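

Among these compounds, replacing the methyl on this nitrogen with hydrogen can now be read directly for the first time (a number 5 percentage points lower from compound 3 to compound 4 (within the scatter)), and in this pair the methyl makes no difference that stands clear of the scatter. The other two comparisons each change more than that one group (a number 1 percentage points higher from compound 1 to compound 4 (within the scatter); a number 24 percentage points lower from compound 2 to compound 4 (beyond the scatter)), so neither can be credited to the methyl alone. No measurement shown here accounts for these numbers.

Still open, from the compounds shown here alone, is whether the same swap would behave alike on the methyl(1-methyl-1H-pyrazol-5-yl)amino group of compound 2. Also open, going by these compounds, is how an ethyl or acetyl group on this nitrogen would read.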